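Moving the two fluorines on the phenoxy ring of compound 2

A few compounds are considered here, and "the series" means these few. Any claim that something is new, unique, unknown or untested is made for them only; others in the source may bear on it.

Compound 1, `O=C1C(=O)N(Cc2ccc(F)cc2)c2ccc(S(=O)(=O)N3CCC[C@H]3COc3ccc(F)cc3)cc21`: in an assay on isolated protein for inhibition of Caspase-8 (Homo sapiens) (on this read-out higher numbers stand for an effect only at larger amounts of compound and lower numbers for an effect already at smaller amounts), a limit of > 5000 nM
Compound 2, `O=C1C(=O)N(Cc2ccc(F)cc2)c2ccc(S(=O)(=O)N3CCC[C@H]3COc3ccc(F)cc3F)cc21`: in this assay a limit of > 5000 nM

Both measured compounds stand at the limit of this assay. Compound 2 gives only a limit, > 5000 nM, and no number. Compound 1 likewise gives only a limit, > 5000 nM. Among the compounds with values here, the single measured step, a step that the two limits leave unreadable from compound 1 to compound 2, is therefore unreadable in size, as the limit of > 5000 nM in this assay, at which 2 of the 2 values shown sit, shows. Compound 3, `O=C1C(=O)N(Cc2ccc(F)cc2)c2ccc(S(=O)(=O)N3CCC[C@H]3COc3cc(F)cc(F)c3)cc21`, keeps the same atoms and differs from compound 2 by 3,5-difluorophenyl in place of 2,4-difluorophenyl on an oxygen on a saturated carbon. Within the data shown here, no measured step speaks to this change, and the step from compound 1 to compound 2 gives no readable direction. Compound 3 is expected to remain at the limit as well, estimated at 8000 nM with a range of 3000 nM to 30000 nM. The expected step is a step that the limit leaves unreadable from compound 2 to compound 3, that is, none that could be read.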

Compound 3, half-maximal effective concentration: > 5000 nM
Compound 3 was reported as a limit; the forecaster's own chance of this, stated with the estimate: 85%; the middle value lies beyond the limit too.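

Compound 3 gives only a limit, so neither its step from compound 1 nor its step from compound 2 can be read; all three compounds rest at one limit: the limit of > 5000 nM in this assay, at which 3 of the 3 values shown sit. From the compounds shown here alone, whether fluorine placement on the phenoxy ring matters at all in this assay stays open.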